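Aryl hydrazone urea series: removing one phenol hydroxy

The source may report more compounds than this note shows. Statements on the series, on what has been measured and on what is new or still open speak of the compounds shown alone.

compound 1 `COc1cc(/C=N/NC(=O)Nc2ccc(Oc3ccnc(-c4nncn4CCN(C)C)c3)c(F)c2)cc(OC)c1OC` gives 2770 nM in a functional assay on NCI-H460 cells (Homo sapiens) for cytotoxicity, read by MTT assay, with a stated time of 72 h; a higher number here means a weaker inhibitor, a lower number a stronger inhibitor
compound 2 `CN(C)CCn1cnnc1-c1cc(Oc2ccc(NC(=O)N/N=C/c3ccc(O)c(O)c3)cc2F)ccn1` gives 1930 nM in this assay

Compound 3 `CN(C)CCn1cnnc1-c1cc(Oc2ccc(NC(=O)N/N=C/c3cccc(O)c3)cc2F)ccn1` awaits measurement. Of the two values in this assay, that of compound 2 is the lower, yet a 1.4-fold lower number from compound 1 to compound 2 (0.16 log units; within the scatter) lies within the scatter, so the two compounds are not separated. The change from compound 2 to compound 3 is hydrogen in place of hydroxy on an aromatic carbon. Among the compounds with values here, no measured step removes a hydroxy on its own; the only step, a 1.4-fold lower number from compound 1 to compound 2 (0.16 log units; within the scatter), swaps the whole aryl group and stays within the scatter. For compound 3 no step beyond the scatter is expected, a 1.1-fold higher number from compound 2 to compound 3 (0.06 log units; within the scatter). Compound 3 is therefore estimated at 2200 nM, between 900 nM and 5500 nM.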

Compound 3, half-maximal inhibitory concentration: 780 nM
For compound 3 the middle estimate is 2.8-fold (0.45 log units) above the measured one; the measured number lies below the stated range.
By their numbers in this assay, from the lowest: compound 3; then compounds 2 and 1 (each within the scatter of the next).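

In this assay, within the data shown here, hydrogen in place of hydroxy on this aromatic carbon gives a 2.5-fold lower number from compound 2 to compound 3 (0.39 log units; beyond the scatter) and is the first single-place change to read beyond the scatter. The 3-hydroxyphenyl group also separates from the 3,4,5-trimethoxyphenyl group, with a 3.6-fold lower number from compound 1 to compound 3 (0.55 log units; beyond the scatter) as the larger step. Nothing available accounts for either step. The compounds shown leave open whether the remaining hydroxy matters to the number, and how an amine or a fluorine on the vacated carbon would read.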